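The source may report more compounds than this note shows. Statements on the series, on what has been measured and on what is new or still open speak of the compounds shown alone.

Measured in a functional assay on MDA-MB-231 cells (Homo sapiens), read by microscopy and transwell migration, with a stated time of 24 h; on this read-out higher numbers stand for weaker inhibition and lower numbers for stronger inhibition:
- Compound 1 `Cc1ccc(-c2cs/c(=N\C(=O)c3ccccc3)n2C)c(C)c1` gives 218 nM
- Compound 2 `CCn1c(-c2ccc(C)cc2C)cs/c1=N\C(=O)c1ccccc1` gives 1950 nM
- Compound 3 `CCCCCCn1c(-c2ccc(C)cc2C)cs/c1=N\C(=O)c1ccccc1` gives 45 nM

Among these three, compound 1 has the second highest number, with compound 2 higher and compound 3 lower. Compound 4 `CCCCCCCCCCCCn1c(-c2ccc(C)cc2C)cs/c1=N\C(=O)c1ccccc1` has not yet been measured. Its difference from compound 1 is undecyl in place of hydrogen on a saturated chain carbon bound to an aromatic nitrogen, with undecyl in place of hydrogen on a saturated chain carbon bound to an aromatic nitrogen.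

Two measured steps make a change of the same kind at that carbon. Methyl there gives an 8.9-fold higher number from compound 1 to compound 2 (0.95 log units; beyond the scatter), a modest rise, whereas pentyl gives a 4.8-fold lower number from compound 1 to compound 3 (0.69 log units; beyond the scatter), a modest fall. The step of a 43-fold lower number from compound 2 to compound 3 (1.64 log units; beyond the scatter) is large. The numbers therefore do not fall steadily as the chain grows, and compound 2 goes against such a pattern. For the measured compounds named here, no measured compound carries a chain as long as that of compound 4, so the estimate must stay wide. Resting on a 4.8-fold lower number from compound 1 to compound 3 (0.69 log units; beyond the scatter), a modest step to a lower number is expected in this assay. The expected step is a 3.6-fold lower number from compound 1 to compound 4 (0.56 log units; beyond the scatter). Compound 4 is estimated at 60 nM, with an expected range of 10 nM to 500 nM.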

Compound 4, half-maximal inhibitory concentration: 24 nM
Beside the measured number, compound 4's estimate is 2.5-fold (0.40 log units) above it; low and high end bracket the measured number.
By their numbers in this assay, from the lowest: compounds 4 and 3 (each within the scatter of the next); then compound 1; then compound 2.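

In this assay, the long undecyl chain on the saturated chain carbon bound to an aromatic nitrogen keeps the clear separation from the hydrogen of compound 1 (a 9.1-fold lower number from compound 1 to compound 4 (0.96 log units; beyond the scatter)) and widens the gap to the short chain of compound 2 (an 81-fold lower number from compound 2 to compound 4 (1.91 log units; beyond the scatter)). For the compounds shown here, what the earlier compounds could not show is that adding a hexyl group further along the chain of compound 3 brings no change that can be told from the scatter (a 1.9-fold lower number from compound 3 to compound 4 (0.27 log units; within the scatter)). Among these compounds, the numbers therefore stop separating once the chain reaches that of compound 3, while compound 2 still goes against any steady fall from compound 1.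

Nothing available here explains these steps. As far as these compounds go, whether a still longer chain, or a chain ending in an amine or a carboxylic acid, would hold this level remains open.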